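The source may report more compounds than this note shows. Statements on the series, on what has been measured and on what is new or still open speak of the compounds shown alone.

Measured in a physicochemical assay for solubility, using the shake flask method, in phosphate buffer, measured as kinetic solubility, with a stated time of 20 h, at pH 6.5; on this read-out higher numbers stand for higher solubility and lower numbers for lower solubility:
- Compound 1 `Fc1ccc(-c2nc3cnc(Nc4ccc(C(F)(F)F)cn4)cc3[nH]2)cc1F`: < 5000 nM, a limit of the assay.
- Compound 2 `FC(F)(F)c1ccc(Nc2cc3[nH]c(C4CCOC4)nc3cn2)nc1`: 166000 nM.

Going by the values given here, compound 2 thus holds the only true number in this assay. Compound 3 `CC1(c2nc3cnc(Nc4ccc(C(F)(F)F)cn4)cc3[nH]2)CC1` carries 1-methylcyclopropyl in place of oxolan-3-yl on an aromatic carbon. Among the compounds with values here, one measured step bears on this change, the large at least 33-fold higher number from compound 1 to compound 2 (1.52 log units; beyond the scatter), which put oxolan-3-yl in place of 3,4-difluorophenyl. Compound 3 keeps a non-aromatic ring there, so a moderate fall is expected, well short of that step. The expected change is a 3.3-fold lower number from compound 2 to compound 3 (0.52 log units; beyond the scatter). For compound 3 the estimate is 50000 nM, with an expected range of 12000 nM to 150000 nM.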

Compound 3, solubility: 188000 nM
Compound 3: middle estimate off by 3.8-fold (0.58 log units), on the low side, and the stated range ends below it.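

In this assay, 1-methylcyclopropyl in place of oxolan-3-yl gives a 1.1-fold higher number from compound 2 to compound 3 (0.05 log units; within the scatter), so these two non-aromatic rings cannot be told apart here, although only oxolan-3-yl carries a hydrogen-bond acceptor. With 1-methylcyclopropyl in place of 3,4-difluorophenyl, the result is an at least 37-fold higher number from compound 1 to compound 3 (1.57 log units; beyond the scatter), so the large step is not tied to oxolan-3-yl alone. Compound 1 stands at a limit of the assay, so this step gives only a bound: the limit of < 5000 nM in this assay, at which 1 of the 3 values shown sits.

From the compounds shown here alone, whether a longer chain or an amine in this place would give values like those of compound 2 and compound 3 remains open.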